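This account rests on a few compounds, and the source may have more. Where it says the series, first, only, none or still open, it means among the compounds named here.

Compound 1 `Cc1c(COc2cccc(OCC3CCOCC3)c2)[nH]c2ccc(C(=O)O)cc2c1=O` gives 400 nM in a functional assay on HUVEC cells (Homo sapiens) for inhibition, using NADPH, with a stated time of 2 h; on this read-out higher numbers stand for weaker inhibition and lower numbers for stronger inhibition.
Compound 2 `CC(C)c1c(COc2cccc(OCC3CCOCC3)c2)[nH]c2ccccc2c1=O` gives 54 nM in this assay.

Of the two measured numbers, compound 1 has the higher one and compound 2 the lower, a gap that lies beyond the usual scatter. Compound 3 `Cc1c(COc2cccc(OCC3CCOCC3)c2)[nH]c2ccc(Cl)cc2c1=O` is not yet measured; it differs from compound 1 by chloro in place of carboxy on an aromatic carbon. Within the data shown here, no measured pair shows this change, so its effect is unknown. A modest move toward stronger inhibition is expected, a 2.0-fold lower number from compound 1 to compound 3 (0.30 log units; within the scatter). Compound 3 is estimated at 200 nM, within a range from 60 nM to 700 nM.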

Compound 3, half-maximal inhibitory concentration: 5 nM
Beside the measured number, compound 3's estimate is 40-fold (1.60 log units) above it, and the stated range ends above it.
By their numbers in this assay, from the lowest: compound 3; then compound 2; then compound 1.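

On the aromatic carbon that is meta to a fused ring and para to a fused ring, chloro in place of carboxy gives an 80-fold lower number from compound 1 to compound 3 (1.90 log units; beyond the scatter) in this assay and so shows that this position strongly affects the read-out. Among these compounds, the step lies beyond the scatter, and it is the first measured change at this position. Nothing available explains why the step is so large.

From the compounds shown here alone, whether fluoro, methoxy or an amine at this position would perform like chloro remains open. So does whether hydrogen here would give a number closer to that of compound 1 or compound 3.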